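A methoxyphenyl swap on compound 2

The source may hold more compounds than are shown below. What is called first, only, known or untested is meant among the compounds shown, and "the series" means these compounds.

In a functional assay on U-87MG ATCC cells for antiproliferative activity against U-87 MG (Homo sapiens), read by MTT assay, with a stated time of 48 h (a higher number here means a weaker inhibitor, a lower number a stronger inhibitor), compound 1 `Cc1nc(-c2ccc(Cl)cc2)sc1C(=O)CSc1nc(-c2ccccc2)c(C#N)c(=O)[nH]1` gives 27600 nM, compound 2 `Cc1nc(-c2ccc(Cl)cc2)sc1C(=O)CSc1nc(-c2ccc(Cl)c(Cl)c2)c(C#N)c(=O)[nH]1` gives 83900 nM and compound 3 `Cc1nc(-c2ccccc2)sc1C(=O)CSc1nc(-c2ccc(Cl)c(Cl)c2)c(C#N)c(=O)[nH]1` gives 65000 nM. Compound 2 therefore shares the weak end of this small set with compound 3, since the step of a 1.3-fold lower number from compound 2 to compound 3 (0.11 log units; within the scatter) does not separate them. Compound 4 `COc1ccc(-c2nc(SCC(=O)c3sc(-c4ccc(Cl)cc4)nc3C)[nH]c(=O)c2C#N)cc1` has not yet been measured. It carries 4-methoxyphenyl in place of 3,4-dichlorophenyl on an aromatic carbon.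

Among the measured compounds shown here, the most relevant evidence is the step of a 3.0-fold higher number from compound 1 to compound 2 (0.48 log units; beyond the scatter), the only measured change at that same carbon. The step of a 1.3-fold lower number from compound 2 to compound 3 (0.11 log units; within the scatter) concerns a different aromatic carbon and offers little guidance. For the measured compounds named here, no measured compound carries 4-methoxyphenyl at this carbon, so the comparison is uncertain. Losing 3,4-dichlorophenyl is expected to undo part of the step seen with compound 1, giving a modest move towards a lower number in this assay. The expected change is a 2.1-fold lower number from compound 2 to compound 4 (0.32 log units; beyond the scatter). Compound 4 is estimated at 40000 nM, within a range of 17000 nM to 95000 nM.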

Compound 4, half-maximal inhibitory concentration: 35500 nM
Estimate against measurement, compound 4: 1.1-fold (0.05 log units) above; measured number inside the range.
By their numbers in this assay, from the lowest: compounds 1, 4, 3 and 2 (each within the scatter of the next, the first and the last beyond it).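

In this assay, 4-methoxyphenyl in place of 3,4-dichlorophenyl gives a 2.4-fold lower number from compound 2 to compound 4 (0.37 log units; beyond the scatter), so the higher number seen with 3,4-dichlorophenyl does not extend to this other substituted phenyl at this carbon. Adding a methoxy group to the plain phenyl gives a 1.3-fold higher number from compound 1 to compound 4 (0.11 log units; within the scatter), so phenyl and 4-methoxyphenyl cannot be told apart in this assay. Nothing available here explains these numbers at the level of mechanism or physical properties.

Still open, as far as these compounds go, is whether a group such as 4-hydroxyphenyl or 4-aminophenyl at this carbon would also stay level with plain phenyl, or would move the number clearly in either direction. From the compounds shown here alone, it is also open whether the methoxy swap would give a similar step in the compound 3 series, where the chloro substituent on the other phenyl is replaced by hydrogen.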